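The compounds below may be only part of what the source reports. "The series", "measured", "known", "first", "only" and "open" are said of these compounds alone.

Measured compounds in an ADME assay on HepG2 2.2.15 cells (Homo sapiens) for cytotoxicity, read by MTT assay, with stated times of 48 h and 9 days; a higher number here means that more compound is tolerated, a lower number that less compound is tolerated:
compound 1 `COc1ccc(CNC(=O)/C=C/c2coc3cc(O)ccc3c2=O)cc1` gives 718000 nM;
compound 2 `COc1ccc2c(=O)c(/C=C/C(=O)Nc3ccccc3Cl)coc2c1` gives 1010000 nM;
compound 3 `COc1ccc2c(=O)c(/C=C/C(=O)NCc3ccccc3F)coc2c1` gives 146000 nM.

Among these three numbers compound 1 stands second highest. Its nearest neighbour is compound 2, whose value lies within the scatter of that of compound 1, so the two cannot be told apart; compound 3 gives the lowest number, and its gap to compound 1 lies beyond the scatter.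

Compound 4 `COc1ccc(CNC(=O)/C=C/c2coc3cc(OC)ccc3c2=O)cc1` is the next compound, and it differs from compound 1 in one place: methyl in place of hydrogen on an oxygen on an aromatic ring. Among the compounds with values here, the only measured step, a 6.9-fold lower number from compound 2 to compound 3 (0.84 log units; beyond the scatter), concerns the group on the amide-type nitrogen and leaves the oxygen on the aromatic ring untouched, so it does not bear on the change from compound 1 to compound 4. Compounds 2 and 3 both carry a methoxy on the core, and their values straddle that of compound 1 on either side, giving no clear signal for the exchange of hydroxy for methoxy. Within the data shown here, with no measured step bearing on this change, compound 4 is expected to show no step beyond the scatter in this assay, that is a 1.0-fold lower number from compound 1 to compound 4 (0.01 log units; within the scatter). The estimate for compound 4 is therefore 700000 nM, with a range from 300000 nM to 1500000 nM.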

Compound 4, half-maximal cytotoxic concentration: 43000 nM
Compound 4: the middle estimate sits 16-fold (1.21 log units) above what was measured; the measured number lies below the stated range.
By their numbers in this assay, from the lowest: compound 4; then compound 3; then compounds 1 and 2 (each within the scatter of the next).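

In this assay, within the data shown here, hydroxy to methoxy on an oxygen on an aromatic ring proves to be a large change, not a silent one (a 17-fold lower number from compound 1 to compound 4 (1.22 log units; beyond the scatter)), even though it adds only one carbon to compound 1 and leaves the rest of the molecule the same. Compounds 2 and 3 carry the methoxy too, yet compound 4 still lies clearly lower than either (a 3.4-fold lower number from compound 3 to compound 4 (0.53 log units; beyond the scatter); a 23-fold lower number from compound 2 to compound 4 (1.37 log units; beyond the scatter)), so the methoxy alone does not set the number and the group on the amide-type nitrogen also counts, with compound 4 now the least tolerated of the four. Nothing available accounts for the size of this step.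

The compounds shown leave open whether a longer chain on that oxygen, such as ethoxy, or an amine in place of the hydroxy would lower the number in the same way. They also leave open whether hydroxy to methoxy has a step of this size when the group on the amide-type nitrogen is 2-chlorophenyl or 2-fluorobenzyl, since the change is seen here in one pair only.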